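Swapping Phenyl for Thiophen-2-yl at a Cytotoxicity Limit

The source may hold more compounds than are shown below. What is called first, only, known or untested is meant among the compounds shown, and "the series" means these compounds.

Three compounds built on a shared core have been examined in an ADME assay on L929 cells (Mus musculus) for cytotoxicity, read by resazurin assay, with a stated time of 72 h; a lower number here means a stronger inhibitor, a higher number a weaker inhibitor. Compound 1, `OB1OCc2ccc(-n3cc(Sc4ccc5ccccc5c4)c4ccccc43)cc21`, gives only a limit there, > 10 ug/mL. Compound 2, `COc1ccc(S(=O)(=O)c2cn(-c3ccc4c(c3)B(O)OC4)c3ccccc23)cc1`, likewise gives only a limit, > 10 ug/mL. Compound 3, `O=C(c1ccccc1)c1ccn(-c2ccc3c(c2)B(O)OC3)c1`, also gives only a limit, > 10 ug/mL, so no exact number is known for it. All three values sit at the limit of > 10 ug/mL in this assay, at which 3 of the 3 values shown sit, and no ordering among compounds 1, 2 and 3 can be drawn from them. Compound 4, `O=C(c1ccn(-c2ccc3c(c2)B(O)OC3)c1)c1cccs1`, has not yet been measured in this assay. It differs from compound 3 in one place: thiophen-2-yl in place of phenyl on a carbonyl carbon. Among the measured compounds shown here, the step that the limit leaves unreadable from compound 3 to compound 4 is expected to stay within the scatter, because every measured value so far rests at the limit of > 10 ug/mL in this assay, at which 3 of the 3 values shown sit. Compound 4 is therefore expected near 20 ug/mL, with a range from 10 ug/mL to 50 ug/mL, most likely reported again as a limit.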

Compound 4, half-maximal inhibitory concentration: > 10 ug/mL
Compound 4 ended at the assay's limit; the forecaster's own chance of this, stated with the estimate: 85%; the middle value lies beyond the limit too.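

The swap of phenyl for thiophen-2-yl gives no readable step between compound 3 and compound 4, because both values are limits: the limit of > 10 ug/mL in this assay, at which 4 of the 4 values shown sit.

Going by these compounds, what exact value any of the four compounds has in this assay remains open.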